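The source may report more compounds than this note shows. Statements on the series, on what has been measured and on what is new or still open speak of the compounds shown alone.

Measured compounds in a functional assay on MOLT-4 cells (Homo sapiens) for cytotoxicity, read by MTT assay, with a stated time of 72 h; on this read-out higher numbers stand for weaker inhibition and lower numbers for stronger inhibition:

- compound 1 `COc1ccc(/C=C/C(=O)c2cc3ccc(OCc4cccc(OC)c4)cc3oc2=O)cc1` gives > 100000 nM, a limit of the assay.
- compound 2 `COc1cccc(COc2ccc3cc(C(=O)/C=C/c4ccc(C)cc4)c(=O)oc3c2)c1` gives > 50000 nM, a limit of the assay.
- compound 3 `COc1cccc(COc2ccc3cc(C(=O)/C=C/c4ccccc4)c(=O)oc3c2)c1` gives > 100000 nM, a limit of the assay.

Compound 3 therefore stands only at a limit in this assay. The two other values in the series are also limits, one of them at a different cutoff, so none of the three compounds can be ordered against another. The steps among them, a step that the two limits leave unreadable from compound 1 to compound 2, a step that the two limits leave unreadable from compound 1 to compound 3 and a step that the two limits leave unreadable from compound 2 to compound 3, are unreadable: the two cutoffs, the limit of > 100000 nM in this assay, at which 2 of the 3 values shown sit, and (the limit of > 50000 nM in this assay, at which 1 of the 3 values shown sits), leave no number on either side.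

Compound 4 `COc1cccc(COc2ccc3cc(C(=O)/C=C/c4c(Cl)cccc4Cl)c(=O)oc3c2)c1` differs from compound 3 by 2,6-dichlorophenyl in place of phenyl on a double-bonded chain carbon bound to a double-bonded chain carbon. Within the data shown here, no measured step touches this part of the molecule; the three measured steps all concern a substituent on an aromatic carbon, and none of them produced a readable number. Among the measured compounds shown here, what bears on the step is only that every compound so far sits at a limit in this assay. The expectation for a number no higher from compound 3 to compound 4 (the limit leaves the size open) is accordingly no step beyond the scatter, unless the entering chlorine atoms open a readable value. Compound 4 is expected at 100000 nM, within 30000 nM to 300000 nM, and most likely reported again as a limit.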

Compound 4, half-maximal inhibitory concentration: 12500 nM
For compound 4 the middle estimate is 8.0-fold (0.90 log units) above the measured one; measured number outside the range, below it.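

In this assay, among these compounds, compound 4 gives 12500 nM, the only readable number so far, which makes the place on a double-bonded chain carbon bound to a double-bonded chain carbon the first where a change shows a measurable effect. The entry of 2,6-dichlorophenyl gives an at least 8.0-fold lower number from compound 3 to compound 4 (0.90 log units; beyond the scatter) in place of phenyl, an at least 4.0-fold lower number from compound 2 to compound 4 (0.60 log units; beyond the scatter) in place of 4-methylphenyl and an at least 8.0-fold lower number from compound 1 to compound 4 (0.90 log units; beyond the scatter) in place of 4-methoxyphenyl as the replaced group. These steps are floors and not sizes, and the steps among compound 1, compound 2 and compound 3 cannot be read, because those compounds stop at cutoffs, the more frequent one being this: the limit of > 100000 nM in this assay, at which 2 of the 4 values shown sit.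

Open, on these data alone, is whether a single chlorine atom on the phenyl would carry the step, and whether bromine atoms, fluorine atoms or an amine on that ring would do the same. Also open, as far as these compounds go, is whether 2,6-dichlorophenyl holds this number with other groups on the rest of the core, as compound 4 is its only carrier here.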